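The source may report more compounds than this note shows. Statements on the series, on what has been measured and on what is new or still open speak of the compounds shown alone.

Measured compounds:
- compound 1 `COc1ccc(-c2cc(/C=C/C(=O)c3ccc(N)cc3)[nH]n2)cc1`: 101%
- compound 2 `COc1cc(-c2cc(/C=C/C(=O)c3ccc(N)cc3)[nH]n2)cc(OC)c1OC`: 96%

In a functional assay on A549 cells (Homo sapiens) for cytotoxicity, read by sulforhodamine B assay, with a stated time of 48 h, tested at 0.01 uM (on this read-out higher numbers stand for a weaker effect at the one concentration tested and lower numbers for a stronger effect), compound 1 gives 101% and compound 2 gives 96%. The value of compound 2 lies within the usual scatter of that of compound 1, so the two cannot be told apart on this assay; both readings sit close to the level of untreated cells at the single concentration tested. Compound 3 `COc1cc(-c2cc(/C=C/C(=O)c3ccc(Cl)c(Cl)c3)[nH]n2)cc(OC)c1OC` has not yet been measured. It differs from compound 2 in one place, on the carbonyl carbon, where (3,4-dichlorophenyl in place of 4-aminophenyl on a carbonyl carbon). Among the compounds with values here, no measured pair in this set shows the effect of such a change, so there is nothing to point to a shift beyond the scatter. The step from compound 2 to compound 3 in this assay is expected to be a number 1 percentage points higher from compound 2 to compound 3 (within the scatter), that is, none beyond the scatter. Compound 3 is therefore estimated at 97%, with a range from 85% to 108%.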

Compound 3, a percentage reported as activity, at one concentration (the size of the read-out at that concentration, not a potency): 101%
Compound 3: middle estimate off by 4 percentage points, on the low side, within the range that was stated.
By their numbers in this assay, from the lowest: compounds 2, 1 and 3 (each within the scatter of the next).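

Within the data shown here, the first change on the carbonyl carbon can now be read: in this assay, putting 3,4-dichlorophenyl in place of 4-aminophenyl gives a number 5 percentage points higher from compound 2 to compound 3 (within the scatter). Exchanging the aminophenyl group, with its hydrogen-bond donor and acceptor, for a ring with two chlorine atoms and neither of these therefore leaves no difference that can be told from the scatter at this one concentration. All the readings shown stay close to the level of untreated cells. Among these compounds, this shows only that neither group produces a detectable effect here, not that the position is unimportant. Nothing available explains the result.

As far as these compounds go, it remains open whether a carboxylic acid or a methoxy group on this phenyl ring would give a different reading. From the compounds shown here alone, it also remains open whether 4-aminophenyl and 3,4-dichlorophenyl would separate at higher concentrations.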